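Benzyl for trifluoromethylphenyl on a second headgroup

A few compounds are considered here, and "the series" means these few. Any claim that something is new, unique, unknown or untested is made for them only; others in the source may bear on it.

Compound 1 `COc1ccc(F)cc1CNCCCNc1ccnc2cc(Cc3ccccc3)ccc12`, compound 2 `COc1ccc(F)cc1CNCCCNc1ccnc2cc(-c3ccc(C(F)(F)F)cc3)ccc12` and compound 3 `COc1cccc(CNCCCNc2ccnc3cc(-c4ccc(C(F)(F)F)cc4)ccc23)c1O` are measured; compound 4 `COc1cccc(CNCCCNc2ccnc3cc(Cc4ccccc4)ccc23)c1O` is not. In an ADME assay on HepG2 cells (Homo sapiens) for cytotoxicity, read by luminescence, CellTiter-Glo and ATP content, with a stated time of 72 h (on this read-out lower numbers stand for an effect already at smaller amounts and higher numbers for an effect only at larger amounts of compound), compound 1 gives 7990 nM, compound 2 gives 5190 nM and compound 3 gives 2210 nM, the lowest of the three. The step of a 2.3-fold lower number from compound 2 to compound 3 (0.37 log units; beyond the scatter) goes with the change (2-hydroxy-3-methoxyphenyl in place of 5-fluoro-2-methoxyphenyl on a saturated chain carbon bound to an amine nitrogen), which is how the two cores differ. The change from compound 3 to compound 4 is benzyl in place of 4-(trifluoromethyl)phenyl on an aromatic carbon. The same change, at the same place, is benzyl in place of 4-(trifluoromethyl)phenyl on an aromatic carbon, and it gave a 1.5-fold higher number from compound 2 to compound 1 (0.19 log units; within the scatter). For compound 4 the step of a 1.5-fold higher number from compound 3 to compound 4 (0.17 log units; within the scatter) is expected to be of similar size, since the earlier step of a 1.5-fold higher number from compound 2 to compound 1 (0.19 log units; within the scatter) stayed within the scatter. Compound 4 is therefore expected to give 3300 nM in this assay, between 1700 nM and 6500 nM.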

Compound 4, half-maximal effective concentration: 5720 nM
For compound 4 the middle estimate is 1.7-fold (0.24 log units) below the measured one; the range from low to high includes it.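

In this assay the change from 4-(trifluoromethyl)phenyl to benzyl gives a 2.6-fold higher number from compound 3 to compound 4 (0.41 log units; beyond the scatter), and it carries over from one core to the other without a resolved difference: the same change on two cores in this assay, a 1.5-fold higher number (0.19 log units; within the scatter) from compound 2 to compound 1 and a 2.6-fold higher number (0.41 log units; beyond the scatter) from compound 3 to compound 4, 1.7-fold (0.23 log units) apart, within the scatter of two such steps. The change of headgroup, read on the benzyl compounds, gives a 1.4-fold lower number from compound 1 to compound 4 (0.15 log units; within the scatter), and it also shows no resolved difference: the same change on two cores in this assay, a 2.3-fold lower number (0.37 log units; beyond the scatter) from compound 2 to compound 3 and a 1.4-fold lower number (0.15 log units; within the scatter) from compound 1 to compound 4, 1.7-fold (0.23 log units) apart, within the scatter of two such steps. This supports treating the two changes as transferable across these four compounds only; a single pair for each change does not show that this holds for other groups or cores.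

Going by these compounds, it remains open whether the same holds for a carboxylic acid or a morpholine on that aromatic carbon. A longer saturated chain on the amine nitrogen is equally untested here.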